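Three Amide Aryl Groups Measured, a Pyridyl One Awaited

The source may hold more compounds than are shown below. What is called first, only, known or untested is meant among the compounds shown, and "the series" means these compounds.

Compound 1 `COc1cc2c(cc1OC)C(CC(=O)Nc1ccc(Cl)cc1)CC2`: 60.9%
Compound 2 `COc1cc2c(cc1OC)C(CC(=O)Nc1cccc(C)c1)CC2`: 40.6%
Compound 3 `COc1ccccc1NC(=O)CC1CCc2cc(OC)c(OC)cc21`: 23.4%

All three were tested in a functional assay on the whole organism (strain Wistar) for inhibition, with Rattus norvegicus as the target, read by paw edema, with a stated time of 4 h, at a dose of 100 mg/kg (a higher number here means more inhibition at the dose given (going by the name of the read-out), a lower number less inhibition), and compound 1 stands highest of the three numbers, the nearest being compound 2, the furthest compound 3. Each change of the aryl group on the amide nitrogen of the shared core lowered the read-out: a number 20.3 percentage points lower from compound 1 to compound 2 (beyond the scatter), and a number 37.5 percentage points lower from compound 1 to compound 3 (beyond the scatter), while between the two lower compounds a number 17.2 percentage points lower from compound 2 to compound 3 (beyond the scatter).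

Compound 4 `COc1cc2c(cc1OC)C(CC(=O)Nc1cccnc1)CC2` carries the same core with pyridin-3-yl in place of 4-chlorophenyl on an amide-type nitrogen. Both measured departures from the 4-chlorophenyl group in compound 1 cut the inhibition beyond the scatter, one modestly and one by a large amount, so a further departure is expected to lower it as well, in a step of modest to large size. On that basis compound 4 is estimated at 38%, between 20% and 58%, which means an expected step of a number 22.9 percentage points lower from compound 1 to compound 4 (beyond the scatter).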

Compound 4, a percentage reported as inhibition, in the whole organism at one dose (the size of the read-out at that dose, not a potency): 34.4%
Compound 4: middle estimate off by 3.6 percentage points, on the high side, within the range that was stated.
By their numbers in this assay, from the lowest: compound 3; then compounds 4 and 2 (each within the scatter of the next); then compound 1.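

In this assay, a ring with a hetero atom on the amide-type nitrogen does not restore what the 4-chlorophenyl group gives, with a number 26.5 percentage points lower from compound 1 to compound 4 (beyond the scatter), so compound 1 keeps a clear lead over all three other aryl groups. Pyridin-3-yl nonetheless reads clear of 2-methoxyphenyl, with a number 11 percentage points higher from compound 3 to compound 4 (beyond the scatter), and cannot be told apart from 3-methylphenyl, with a number 6.2 percentage points lower from compound 2 to compound 4 (within the scatter), so this change places compound 4 level with compound 2 and not at the bottom of the series. Nothing measured here explains why the aryl groups fall in this way.

Still open, on these data alone, is whether the higher number of compound 1 rests on the chlorine or on where it sits, which 3-chlorophenyl and 4-methylphenyl would help to separate. Also open, as far as these compounds go, is how pyridin-4-yl or a saturated cyclohexyl group would read at the same nitrogen.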